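The compounds below may be only part of what the source reports. "The series", "measured", "known", "first", "only" and "open" are said of these compounds alone.

Compound 1, `COC(=O)c1ccc(-c2cnc(C(=O)CCc3ccc(-c4ccccc4)cc3)o2)nc1`: 2.2 nM
Compound 2, `COC(=O)c1ccc(-c2cnc(C(=O)CCc3ccc(COc4ccccc4)cc3)o2)nc1`: 3.5 nM
Compound 3, `O=C(CCc1ccc(Oc2ccccc2)cc1)c1ncc(I)o1`: 10 nM

In an assay for inhibition of Fatty-acid amide hydrolase 1 (Rattus norvegicus) (a higher number here means a weaker inhibitor, a lower number a stronger inhibitor), compound 3 gives the highest number of the three, with compound 2 nearest and compound 1 furthest. Compound 4, `COC(=O)c1ccc(-c2cnc(C(=O)CCc3ccc(Oc4ccccc4)cc3)o2)nc1`, is not yet measured. It differs from compound 3 in one place: 5-(methoxycarbonyl)pyridin-2-yl in place of iodo on an aromatic carbon. Within the data shown here, no measured step covers this exchange; the only measured step, a 1.6-fold higher number from compound 1 to compound 2 (0.20 log units; within the scatter), concerns a different part of the molecule. Compounds 1 and 2, which carry the entering group, both give lower numbers in this assay than compound 3. On that basis a lower number is expected for compound 4, a step of a 3.3-fold lower number from compound 3 to compound 4 (0.52 log units; beyond the scatter). Compound 4 is estimated at 3 nM, in the range 1 nM to 10 nM.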

Compound 4, inhibition constant: 54 nM
Beside the measured number, compound 4's estimate is 18-fold (1.26 log units) below it; measured number above the stated range.
By their numbers in this assay, from the lowest: compounds 1 and 2 (each within the scatter of the next); then compound 3; then compound 4.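

In this assay the 5-(methoxycarbonyl)pyridin-2-yl group does not improve on iodo at this carbon when phenoxy is present, and the number rises (a 5.4-fold higher number from compound 3 to compound 4 (0.73 log units; beyond the scatter)). Phenoxy also gives a much higher number than phenoxymethyl (a 15-fold higher number from compound 2 to compound 4 (1.19 log units; beyond the scatter)) or phenyl (a 25-fold higher number from compound 1 to compound 4 (1.39 log units; beyond the scatter)), a sensitivity that the close values of compounds 1 and 2 did not reveal. No measurement here explains these changes. On these data alone, it remains open how a carboxylic acid in place of the methyl ester would behave, or an amine on the pyridine ring.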